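The compounds below may be only part of what the source reports. "The series", "measured", "known", "first", "only" and "open" are said of these compounds alone.

Three compounds built on the shared core were tested in an assay on HEK293 cells for inhibition of N-acylethanolamine-hydrolyzing acid amidase (Rattus norvegicus), read by LC-MS, with a stated time of 30 min; a lower number here means a stronger inhibitor, a higher number a weaker inhibitor. Compound 1 `O=C(CCCCCCc1ccccc1Cl)N1CCCC1` reaches only a limit of the assay, > 100000 nM, so no number is known for it. Compound 2 `Cc1cccc(-c2ccc(CCC(=O)N3CCCC3)cc2)c1` gives 16500 nM. Compound 3 `O=C(CCc1ccc(-c2ccc(F)cc2)cc1)N1CCCC1` gives 3400 nM, the lowest of the two numbers shown, and the only measured step, a 4.9-fold lower number from compound 2 to compound 3 (0.69 log units; beyond the scatter), shows that swapping one substituted outer ring for another can move the number beyond the scatter.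

Compound 4 `O=C(CCc1ccc(-c2cccs2)cc1)N1CCCC1` has not yet been measured. It differs from compound 3 by thiophen-2-yl in place of 4-fluorophenyl on an aromatic carbon. Going by the values given here, no measured step exchanges a six-membered outer ring for a five-membered one, so the measured step offers only a loose guide: a change on the outer ring moved the number by roughly a 4.9-fold lower number from compound 2 to compound 3 (0.69 log units; beyond the scatter). The step from compound 3 to compound 4 is therefore expected to be small, near a 1.5-fold higher number from compound 3 to compound 4 (0.17 log units; within the scatter). Compound 4 is estimated to give about 5000 nM, with a likely range from 1500 nM to 20000 nM.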

Compound 4, half-maximal inhibitory concentration: > 100000 nM
Compound 4 gave a limit, no number; the forecaster's own chance of this, stated with the estimate: 5%; middle value at least 20-fold (1.30 log units) from the limit.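

In this assay, going by these compounds alone, the outer ring at this position proves far less forgiving than the earlier compounds suggested: thiophen-2-yl in place of 4-fluorophenyl gives an at least 29-fold higher number from compound 3 to compound 4 (1.46 log units; beyond the scatter), and in place of 3-methylphenyl it gives an at least 6.0-fold higher number from compound 2 to compound 4 (0.78 log units; beyond the scatter). The earlier step only exchanged one substituted six-membered ring for another, whereas this change brings in a five-membered aromatic ring with one hetero atom, and the measurable inhibition of compounds 2 and 3 is no longer seen. Both steps give only a minimum size, because compound 4 reaches a limit of the assay: the limit of > 100000 nM in this assay, at which 2 of the 4 values shown sit.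

The compounds shown leave open whether the loss follows the smaller ring or its sulfur atom, a question that a furan-2-yl or an unsubstituted phenyl ring could help to settle. From the compounds shown here alone, it also remains open whether an amine on the outer ring would be tolerated here.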